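A Smaller Substituent Replaces Benzyloxy on a Nitro Ring

The compounds below may be only part of what the source reports. "The series", "measured", "known", "first", "only" and "open" are said of these compounds alone.

Three compounds built on a shared core have been examined in an assay for inhibition of Tryptophan 2,3-dioxygenase (Homo sapiens), with stated times of 10 min and 60 min, tested at 100 uM; a lower number here means a weaker effect, a higher number a stronger effect of the compound at the concentration tested. Compound 1 (`Oc1ccc(CNc2cc(C(F)(F)F)cc3[nH]ncc23)cc1`) gives 91%. Compound 3 (`O=[N+]([O-])c1cccc(CNc2cc(C(F)(F)F)cc3[nH]ncc23)c1`) gives 82%. Compound 2 (`O=[N+]([O-])c1cc(OCc2ccccc2)ccc1CNc1cc(C(F)(F)F)cc2[nH]ncc12`) gives 55%, the lowest of the three numbers: compound 3 stands above it by a gap beyond the scatter, and compound 1 stands further above it, also beyond the scatter.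

Compound 4 (`O=[N+]([O-])c1cc(Cl)ccc1CNc1cc(C(F)(F)F)cc2[nH]ncc12`) has not yet been measured. It differs from compound 2 in one place: chloro in place of benzyloxy on an aromatic carbon. For the measured compounds named here, no step between measured compounds matches this change, so the expectation rests only on where compound 2 stands against compound 3 and compound 1. The expected step is a number 17 percentage points higher from compound 2 to compound 4 (beyond the scatter), upward and beyond the scatter. Compound 4 is therefore estimated at 72%, within a range from 50% to 90%.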

Compound 4, a percentage reported as inhibition, at one concentration (the size of the read-out at that concentration, not a potency): 93%
Beside the measured number, compound 4's estimate is 21 percentage points below it, outside the stated range (above it).
By their numbers in this assay, from the lowest: compound 2; then compounds 3, 1 and 4 (each within the scatter of the next, the first and the last beyond it).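

Replacing benzyloxy with chloro on this aromatic carbon, meta to a nitro group and para to a large group, gives a number 38 percentage points higher from compound 2 to compound 4 (beyond the scatter) in a single change. The lower reading of compound 2 therefore does not hold for every substituent at this position: this one accepts chloro, and the reading depends on which group sits there. No measurement here gives a reason for the step. 

Going by these compounds, what stays open is which part of benzyloxy matters. A methoxy group, which keeps the oxygen without the aromatic ring, or an amine at this carbon could show whether the reading follows compound 2 or compound 4.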